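Side chain change from compound 3 to compound 4

This account rests on a few compounds, and the source may have more. Where it says the series, first, only, none or still open, it means among the compounds named here.

Among the compounds with values here, in an ADME assay on HEK-293T cells (Homo sapiens) for cytotoxicity, read by luminescence, with a stated time of 24 h (on this read-out lower numbers stand for higher toxicity in this test and higher numbers for lower toxicity in this test), compound 3 `CCCCC(=O)C1CCN(C(=O)c2cc3sccc3n2Cc2ccc(OC)cc2)CC1` gives 38900 nM, the only true number so far. Compound 1 `COc1ccc(Cn2c(C(=O)N3CCC(C(=O)O)CC3)cc3sccc32)cc1` reads > 100000 nM, which is a limit of the assay. Compound 2 `COc1ccc(Cn2c(C(=O)N3CCC(C(=O)NCc4cccc(Br)c4)CC3)cc3sccc32)cc1` reads > 100000 nM, also a limit. Compound 4 `COc1ccc(Cn2c(C(=O)N3CCC(C(=O)NCCC(C)C)CC3)cc3sccc32)cc1` differs from compound 3 by isopentylamino in place of butyl on a carbonyl carbon. The measured steps that bear on this are an at least 2.5-fold lower number from compound 1 to compound 3 (0.41 log units; beyond the scatter) and an at least 2.5-fold lower number from compound 2 to compound 3 (0.41 log units; beyond the scatter), while a step that the two limits leave unreadable from compound 1 to compound 2 says nothing. Compound 4 restores an amino group on that carbonyl carbon, as in compound 2, so the step read in reverse, an at least 2.5-fold lower number from compound 2 to compound 3 (0.41 log units; beyond the scatter), suggests a modest rise. The expected change is a 2.3-fold higher number from compound 3 to compound 4 (0.36 log units; beyond the scatter). For compound 4 the estimated value is 90000 nM, with an expected range of 35000 nM to 200000 nM.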

Compound 4, half-maximal cytotoxic concentration: 30900 nM
Compound 4: the middle estimate sits 2.9-fold (0.46 log units) above what was measured, and the stated range ends above it.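

In this assay, an amide at this carbonyl carbon does not by itself bring the number up to a limit of the assay: a 1.3-fold lower number from compound 3 to compound 4 (0.10 log units; within the scatter). What is carried on the amide nitrogen also counts, as seen in an at least 3.2-fold lower number from compound 2 to compound 4 (0.51 log units; beyond the scatter), while replacing the acid gives an at least 3.2-fold lower number from compound 1 to compound 4 (0.51 log units; beyond the scatter). Compound 1 and compound 2 each read as a limit, so these two steps give only a minimum size: the limit of > 100000 nM in this assay, at which 2 of the 4 values shown sit.

On these data alone, it remains open whether a longer chain or a cyclic amine such as morpholine on this carbonyl carbon would stay within the scatter of compound 4.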